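Trimethoxychalcone imidazolone series: growth inhibition notes

This account rests on a few compounds, and the source may have more. Where it says the series, first, only, none or still open, it means among the compounds named here.

Measured so far:
- compound 1, `COc1cc(/C=C/C(=O)c2cccc(-n3cc(-c4ccccc4)[nH]c3=O)c2)cc(OC)c1OC`: 1380 nM
- compound 2, `COc1ccc(-c2cn(-c3cccc(C(=O)/C=C/c4ccc(O)c(OC)c4)c3)c(=O)[nH]2)cc1`: 4530 nM

Compound 1 gives the lowest of the two numbers in a functional assay on 786-0 cells (Homo sapiens) for inhibition; on this read-out lower numbers stand for stronger inhibition of growth and higher numbers for weaker inhibition of growth. For the measured compounds named here, compound 2 sits beyond the scatter from it in the direction of weaker growth inhibition; compound 2 differs from compound 1 in more than one place, so no single step between them can be read.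

Compound 3, `COc1cc(/C=C/C(=O)c2cccc(-n3cc(-c4cc(OC)c(OC)c(OC)c4)[nH]c3=O)c2)cc(OC)c1OC`, remains to be tested in this assay. It differs from compound 1 by 3,4,5-trimethoxyphenyl in place of phenyl on an aromatic carbon. Going by the values given here, no pair among the measured compounds isolates this exchange, so there is no measured step to lean on. Compound 2 carries a methoxy-substituted ring on the same aromatic carbon and gives a higher number, but its chalcone part also differs, so it offers no clean guidance.

Compound 3 is expected to stay close to compound 1, with the step from compound 1 to compound 3 estimated at a 1.2-fold higher number from compound 1 to compound 3 (0.06 log units; within the scatter), most likely within the scatter. The value of compound 3 in this assay is estimated at 1600 nM, with a range from 500 nM to 5000 nM.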

Compound 3, concentration for 50% growth inhibition: 1590 nM
For compound 3 the middle estimate is 1.0-fold (0.00 log units) above the measured one; measured number inside the range.
By their numbers in this assay, from the lowest: compounds 1 and 3 (each within the scatter of the next); then compound 2.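

In this assay, for the compounds shown here, 3,4,5-trimethoxyphenyl in place of phenyl on an aromatic carbon of the five-membered aromatic ring with 2 nitrogen gives a 1.2-fold higher number from compound 1 to compound 3 (0.06 log units; within the scatter), the first reading at this position with the rest of the molecule held fixed. The read-out therefore does not separate the two groups, even though the entering group adds heavy atoms and 3 hydrogen-bond acceptors, and this position accommodates the larger aryl group without a change beyond the scatter. Nothing measured here explains this outcome.

From the compounds shown here alone, compound 2 differs from compound 1 and from compound 3 in more than one place, so neither comparison can be read as a single step, and it remains open whether the same result would hold with the chalcone part of compound 2. The compounds shown also leave open what a carboxylic acid or a dimethylamino group on this aryl ring would do, and whether a longer alkyl chain in place of the ring would hold the read-out at the level of compound 1 and compound 3.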